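Replacing the methoxyphenyl on the ring amine with cyclohexyl

The compounds below may be only part of what the source reports. "The series", "measured", "known", "first", "only" and "open" are said of these compounds alone.

Three benzamides sharing one core have been measured in a functional assay on HeLa cells (Homo sapiens) for antiproliferative activity, read by CCK-8 assay, with a stated time of 72 h, tested at 2 uM; on this read-out higher numbers stand for a stronger effect at the one concentration tested and lower numbers for a weaker effect. Compound 2 `COc1ccc(N2CCN(C(=S)SCc3ccc(C(=O)Nc4ccccc4N)cc3)CC2)cc1` gives 39.4% and stands highest of the three. Compound 3 `CN(Cc1cccnc1)C(=S)SCc1ccc(C(=O)Nc2ccccc2N)cc1` gives 16.4%, a number below compound 2 by more than the usual scatter. Compound 1 `Nc1ccccc1NC(=O)c1ccc(CSC(=S)N2CCN(C(c3ccccc3)c3ccccc3)CC2)cc1` gives 8%, the furthest below compound 2, again beyond the scatter.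

Compound 4 `Nc1ccccc1NC(=O)c1ccc(CSC(=S)N2CCN(C3CCCCC3)CC2)cc1` has not yet been measured. It differs from compound 2 in one place: cyclohexyl in place of 4-methoxyphenyl on an amine nitrogen in a ring. Within the data shown here, no measured pair in this set differs in exactly this way, so the size of the step is not known. Among the measured compounds shown here, since compound 1, the only other compound carrying a group on that ring nitrogen, gives 8%, a fall is expected rather than a rise, though the step may still lie within the scatter. The step is estimated as a number 17.4 percentage points lower from compound 2 to compound 4 (beyond the scatter). For compound 4 the estimate in this assay is 22%, with a range from 5% to 42%.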

Compound 4, a percentage reported as inhibition, at one concentration (the size of the read-out at that concentration, not a potency): 30.6%
For compound 4 the middle estimate is 8.6 percentage points below the measured one; measured number inside the range.
By their numbers in this assay, from the lowest: compounds 1 and 3 (each within the scatter of the next); then compounds 4 and 2 (each within the scatter of the next).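

In this assay, cyclohexyl in place of 4-methoxyphenyl on the amine nitrogen in the ring gives a number 8.8 percentage points lower from compound 2 to compound 4 (within the scatter). At this position, then, the read-out at the one tested concentration does not depend on the aromatic ring or the methoxy oxygen of compound 2, since compound 4 carries a non-aromatic ring of carbon only, with no hydrogen-bond acceptor, and stays within the scatter of compound 2. No measured property of either group bears on this result.

As far as these compounds go, whether a much shorter group on this nitrogen, such as methyl or acetyl, or a hydroxyl group on the cyclohexyl ring would give a similar read-out remains open. From the compounds shown here alone, with a single concentration and no potency values, any difference in potency between compound 2 and compound 4 also remains open.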